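The source may report more compounds than this note shows. Statements on the series, on what has been measured and on what is new or still open speak of the compounds shown alone.

The measured compounds are three.
In a functional assay on DU-145 cells (Homo sapiens) for inhibition, read by MTT assay, with a stated time of 72 h (on this read-out higher numbers stand for weaker inhibition of growth and lower numbers for stronger inhibition of growth), compound 1 `N#C/C(=C\c1c(F)c(F)c(F)c(F)c1F)C(=O)c1ccc[nH]1` reaches only the limit > 100000 nM, which is a limit of the assay and not a number.
In this assay compound 2 `N#C/C(=C\c1ccc([N+](=O)[O-])cc1)C(=O)c1c[nH]c2ccccc12` gives 59000 nM.
In this assay compound 3 `COc1ccc(CNC(=O)/C(C#N)=C/c2ccc[nH]2)cc1` reaches only the limit > 50000 nM, again a limit and not a number.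

Compound 3 therefore has no number of its own in this assay; it sits at the limit of > 50000 nM in this assay, at which 1 of the 3 values shown sits, while a second compound sits at the limit of > 100000 nM in this assay, at which 1 of the 3 values shown sits. The one true number in the set, from compound 2, stands for weak inhibition of growth, and nothing shown tells how far beyond its limit compound 3 lies or how it orders against the other two.

Compound 4 `COc1ccc(CNC(=O)/C(C#N)=C/c2ccc(Cl)o2)cc1` is not yet measured. It differs from compound 3 by 5-chlorofuran-2-yl in place of 1H-pyrrol-2-yl on a double-bonded chain carbon bound to a double-bonded chain carbon. For the measured compounds named here, no measured pair shows this change, so no size of step can be read off. Given that compound 3 gives only > 50000 nM and the whole set shows weak inhibition, compound 4 is expected to show no step beyond the scatter, an expected step that the limit leaves unreadable from compound 3 to compound 4. Compound 4 is thus estimated at 60000 nM, within 15000 nM to 200000 nM.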

Compound 4, concentration for 50% growth inhibition: 12000 nM
Beside the measured number, compound 4's estimate is 5.0-fold (0.70 log units) above it; measured number below the stated range.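

In this assay, the swap of 1H-pyrrol-2-yl for 5-chlorofuran-2-yl gives an at least 4.1-fold lower number from compound 3 to compound 4 (0.61 log units; beyond the scatter), so the growth-inhibition read-out does respond to the group at this position. For the compounds shown here, this is the first step in the set that can be read between compounds differing in one place, since the earlier compounds differ from one another in more than one place and could show nothing about a single position. Compound 3 has only a limit and not a number, so this step sets a minimum and its full size stays unknown: the limit of > 50000 nM in this assay, at which 1 of the 4 values shown sits.

The change alters several things at once: the ring hetero atom goes from nitrogen to oxygen, a chlorine enters, and the hydrogen-bond donor of the leaving ring is lost, so the compounds shown cannot say which of these carries the step, a question that a plain furan-2-yl or a 5-methylfuran-2-yl at this position would bear on. On these data alone, it also remains open whether the same step would appear if the amide of compounds 3 and 4 gave way to a carboxylic acid or a longer chain.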